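Bromo Added to the Phenyl Ring of a Triazole Compound

This account rests on a few compounds, and the source may have more. Where it says the series, first, only, none or still open, it means among the compounds named here.

Measured so far:
Compound 1 `Cc1ccccc1Nc1nc(SCc2cn(Cc3ccccc3Cl)nn2)nc(-c2ccccc2)c1C#N` gives 7280 nM.
Compound 2 `Cc1ccc(Nc2nc(SCc3cn(Cc4ccc(Cl)cc4)nn3)nc(-c3ccccc3)c2C#N)cc1` gives 19600 nM.
Compound 3 `Cc1ccc(Nc2nc(SCc3cn(Cc4ccccc4Cl)nn3)nc(-c3ccccc3)c2C#N)cc1` gives 7190 nM.

These three compounds share one core and were tested in a functional assay on MGC-803 cells (Homo sapiens) for inhibition, read by MTT assay, with a stated time of 72 h; on this read-out higher numbers stand for weaker inhibition and lower numbers for stronger inhibition. Compound 3 has the lowest of the three numbers, but its gap to compound 1 is within the scatter of repeated measurements, so the two cannot be told apart; only compound 2 stands clearly apart, with a higher number.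

The two measured steps concern other parts of the core. The step of a 1.0-fold lower number from compound 1 to compound 3 (0.01 log units; within the scatter) changed where the methyl sits on the aniline ring and made no difference beyond the scatter. The step of a 2.7-fold lower number from compound 2 to compound 3 (0.44 log units; beyond the scatter) moved the chloro on the benzyl group and gave a modest lowering.

Compound 4 `Cc1ccc(Nc2nc(SCc3cn(Cc4ccccc4Cl)nn3)nc(-c3ccc(Br)cc3)c2C#N)cc1` differs from compound 3 by bromo in place of hydrogen on an aromatic carbon. Neither measured step touches this phenyl ring, so nothing in the data speaks for or against a change there. In the absence of any bearing step, the expected step of a 1.0-fold higher number from compound 3 to compound 4 (0.00 log units; within the scatter) is none beyond the scatter. The estimate for compound 4 in this assay is therefore 7200 nM, with a range from 3000 nM to 18000 nM.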

Compound 4, half-maximal inhibitory concentration: 15600 nM
Beside the measured number, compound 4's estimate is 2.2-fold (0.34 log units) below it, within the range that was stated.
By their numbers in this assay, from the lowest: compounds 3 and 1 (each within the scatter of the next); then compounds 4 and 2 (each within the scatter of the next).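

In this assay, the change from phenyl to 4-bromophenyl gives a 2.2-fold higher number from compound 3 to compound 4 (0.34 log units; beyond the scatter), so this ring can affect the read-out even though neither earlier step touched it. A single added bromo on an aromatic carbon, para to a large group, is enough to move the number beyond the scatter, which makes this ring a second place where one change registers, alongside the chloro move on the benzyl group and unlike the methyl move on the other ring. The direction here is toward weaker inhibition, and nothing measured in this set shows what lies behind that shift.

Going by these compounds, with only bromo at this place, it remains open whether the rise is particular to bromo or would also appear with fluoro, a methoxy group or an amine on the same carbon. On these data alone, it is equally open whether bromo would give a similar step on the core of compound 1, which carries its methyl at a different place, or on the core of compound 2, which carries its chloro at a different place.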